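The compounds below may be only part of what the source reports. "The series", "measured", "known", "first", "only" and "open" are said of these compounds alone.

Compound 1 `O=C(Nc1ccc(F)cc1)c1c(NO)cc(-c2ccccc2)oc1=O` and compound 2 `O=C(Nc1ccc(Cl)cc1)c1c(NO)cc(-c2ccccc2)oc1=O` share a core and differ in one place, described as chloro in place of fluoro on an aromatic carbon. In an ADME assay on Huh-7 cells (Homo sapiens) for cytotoxicity, read by a luciferase reporter and WST assay, with a stated time of 3 days (on this read-out higher numbers stand for lower toxicity in this test and lower numbers for higher toxicity in this test), compound 1 gives only a limit, > 20000 nM. In this assay compound 2 likewise gives only a limit, > 20000 nM. The step that the two limits leave unreadable from compound 1 to compound 2 therefore cannot be sized, because of the limit of > 20000 nM in this assay, at which 3 of the 3 values shown sit. Compound 3 `COC(=O)CNC(=O)c1c(NO)cc(-c2ccc(F)cc2)oc1=O` carries a different core; the difference between the two cores is not broken down here. In this assay compound 3 also gives only a limit, > 20000 nM. Compound 4 `COC(=O)CNC(=O)c1c(NO)cc(-c2ccc(Cl)cc2)oc1=O` is related to compound 3 by the same change, (chloro in place of fluoro on an aromatic carbon). Since compound 3 already sits at the limit, compound 4 is expected to remain there too, with an estimated step that the limit leaves unreadable from compound 3 to compound 4 and an expected value of about 30000 nM, between 15000 nM and 90000 nM.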

Compound 4, half-maximal cytotoxic concentration: > 20000 nM
Compound 4 ended at the assay's limit (the forecaster's own chance of this, stated with the estimate: 85%); the middle value does not contradict the limit.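

No size can be read for the step from compound 3 to compound 4, because both compounds give only a limit in this assay: the limit of > 20000 nM in this assay, at which 4 of the 4 values shown sit.

The compounds shown leave open whether chloro in place of fluoro changes cytotoxicity at all, and at what concentration any of them harms these cells.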